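This account rests on a few compounds, and the source may have more. Where it says the series, first, only, none or still open, it means among the compounds named here.

Working notes on a small coumarin-free description: three measured compounds and one awaiting measurement. Compound 1 `CCOc1cc(=O)oc2cc(OCc3cccc(Cl)c3)ccc12` gives 2% in an assay on isolated protein (strain Sprague-Dawley) for inhibition of Amine oxidase [flavin-containing] A (Rattus norvegicus), read by spectrophotometry, with a stated time of 5 min, tested at 10 uM; a lower number here means less inhibition, a higher number more inhibition at the concentration tested (going by the name of the read-out). Compound 2 `CCOc1cc(=O)oc2cc(OCc3cccc(Br)c3)ccc12` gives 2.5% in this assay; the change between them is bromo in place of chloro on an aromatic carbon, and the step is a number 0.5 percentage points higher from compound 1 to compound 2 (within the scatter). Compound 3 `O=c1cc(CCl)c2ccc(OCc3cccc(Cl)c3)cc2o1` gives 21% in this assay. Its core differs from the core of compound 1 by chloromethyl in place of ethoxy on an aromatic carbon, and the step is a number 19 percentage points higher from compound 1 to compound 3 (beyond the scatter). Compound 3 stands highest of the three numbers, with the step to compound 2 and to compound 1 both beyond the scatter.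

Compound 4 `O=c1cc(CCl)c2ccc(OCc3cccc(Br)c3)cc2o1` differs from compound 3 by bromo in place of chloro on an aromatic carbon. This is the same change as that from compound 1 to compound 2, made twice in all among these compounds, at a place described in the same words. The expectation for compound 4 rests on the earlier step, a number 0.5 percentage points higher from compound 1 to compound 2 (within the scatter), which lies within the scatter. For compound 4 the expected step in this assay is a number 1 percentage points higher from compound 3 to compound 4 (within the scatter). Compound 4 is therefore estimated at 22%, with a range from 10% to 34%.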

Compound 4, a percentage reported as inhibition, at one concentration (the size of the read-out at that concentration, not a potency): 28%
Beside the measured number, compound 4's estimate is 6 percentage points below it; low and high end bracket the measured number.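

In this assay, bromo in place of chloro on an aromatic carbon stays within the scatter on both cores, the new step being a number 7 percentage points higher from compound 3 to compound 4 (within the scatter), and the two readings of this change agree: the same change on two cores in this assay, a number 0.5 percentage points higher (within the scatter) from compound 1 to compound 2 and a number 7 percentage points higher (within the scatter) from compound 3 to compound 4, 6.5 percentage points apart, within the scatter of two such steps. Chloromethyl in place of ethoxy also carries over from the chloro pair to the bromo pair, the new step being a number 25.5 percentage points higher from compound 2 to compound 4 (beyond the scatter), and these two readings agree as well: the same change on two cores in this assay, a number 19 percentage points higher (beyond the scatter) from compound 1 to compound 3 and a number 25.5 percentage points higher (beyond the scatter) from compound 2 to compound 4, 6.5 percentage points apart, within the scatter of two such steps. Across these four compounds, then, the two changes behave independently of each other, but this rests on only two readings per change at one tested concentration and gives neither a potency nor any prediction for a core outside this set.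

Still open, from the compounds shown here alone, is whether a fluoro or a methoxy in place of chloro on the aromatic carbon would give a step of the same size. Also open, going by these compounds, is whether an amine or a longer chain in place of chloromethyl would keep the step seen with chloromethyl.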